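Swapping a Sulfonyl for a Carbonyl on Compound 2

The source may report more compounds than this note shows. Statements on the series, on what has been measured and on what is new or still open speak of the compounds shown alone.

Of the compounds shown here, two have so far been measured in a functional assay on MGC-803 cells (Homo sapiens) for inhibition, read by MTT assay, with a stated time of 48 h; on this read-out higher numbers stand for weaker inhibition and lower numbers for stronger inhibition. Compound 1 `COc1ccc(CN(c2cc(OC)c(OC)c(OC)c2)S(=O)(=O)c2c(C)cc(C)cc2C)cc1` gives 6440 nM in this assay. Compound 2 `COc1cc(N(Cc2nc3ccccc3[nH]2)S(=O)(=O)c2ccc(F)cc2)cc(OC)c1OC` gives 5680 nM in this assay. Compound 2 carries the lower of the two numbers, but its nearest neighbour is compound 1, and the gap between them lies within the scatter of repeated measurements, so the two cannot be told apart on this evidence.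

Compound 3 `COc1cc(N(Cc2nc3ccccc3[nH]2)C(=O)c2cccc(Cl)c2)cc(OC)c1OC` has not yet been measured. It differs from compound 2 in one place: (3-chlorophenyl)carbonyl in place of (4-fluorophenyl)sulfonyl on a nitrogen on an aromatic ring. Among the compounds with values here, no step between measured compounds has been recorded, so the size of this change has no precedent within the set and can only be guessed. The expected step is a 1.3-fold lower number from compound 2 to compound 3 (0.10 log units; within the scatter), which would amount to no shift beyond the scatter, with the uncertainty spread on both sides. For compound 3 the estimate in this assay is 4500 nM, with a range from 1200 nM to 16000 nM.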

Compound 3, half-maximal inhibitory concentration: > 50000 nM
Compound 3 was reported as a limit; the forecaster's own chance of this, stated with the estimate: 10%; middle value at least 11-fold (1.04 log units) away from the limit.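

In this assay compound 3 gives > 50000 nM as a limit of the assay, not as a number. The earlier compounds shown here offered no step at all, since they differ in more than one place and their values lie within the scatter of each other, whereas this change on a nitrogen on an aromatic ring gives an at least 8.8-fold higher number from compound 2 to compound 3 (0.94 log units; beyond the scatter) and so shows that the group held at this position matters for the read-out. The size of that step has only a lower bound and rests on a single value at the edge of what the assay reports: the limit of > 50000 nM in this assay, at which 1 of the 3 values shown sits.

The change exchanges the sulfonyl for a carbonyl and, in the same step, the 4-fluorophenyl ring for a 3-chlorophenyl ring, so the compounds shown cannot tell which of these two parts accounts for the weaker inhibition. On these data alone, a (4-fluorophenyl)carbonyl or a (3-chlorophenyl)sulfonyl on the same nitrogen would separate the two, and how far compound 3 actually lies beyond its limit remains unknown.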